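This account rests on a few compounds, and the source may have more. Where it says the series, first, only, none or still open, it means among the compounds named here.

Of the compounds shown here, three have so far been tested in an ADME assay on MT4 cells (Homo sapiens) for cytotoxicity, read by MTT assay, with a stated time of 96 h; on this read-out lower numbers stand for higher toxicity in this test and higher numbers for lower toxicity in this test. Compound 1, with the structure `FC(F)(F)c1cccc(/N=N/c2ccc(NC[C@@H]3CCCN4CCCC[C@H]34)c3c2CCCC3)c1`, gives 15000 nM in this assay. Compound 2, with the structure `CN(C)CCCN(/N=N/c1cc(F)ccc1F)c1ccccc1`, gives 13000 nM in this assay. Compound 3, with the structure `c1ccc(/N=N/N2CCCC2)cc1`, reaches only > 100000 nM in this assay, which is a limit and not a number. Of the two numbers that are known, compound 1 has the higher, with compound 2 lying nearest to it; the gap between the two sits within the usual scatter, so no order between them can be claimed. The remaining value is the limit of > 100000 nM in this assay, at which 1 of the 3 values shown sits.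

Compound 4, with the structure `Fc1ccc(F)c(/N=N/c2ccc(NC[C@@H]3CCCN4CCCC[C@H]34)c3c2CCCC3)c1`, shares the core of compound 1 and differs from it in one place: 2,5-difluorophenyl in place of 3-(trifluoromethyl)phenyl on a double-bonded nitrogen. For the measured compounds named here, no measured pair of compounds shows the effect of such a change, so the step from compound 1 to compound 4 in this assay is expected to be small, with no change beyond the scatter: no change at the digits printed from compound 1 to compound 4 (within the scatter). On that basis compound 4 is estimated to give 15000 nM in this assay, within a range of 6000 nM to 40000 nM.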

Compound 4, half-maximal cytotoxic concentration: 40000 nM
Beside the measured number, compound 4's estimate is 2.7-fold (0.43 log units) below it; the measured number falls inside the stated range.
By their numbers in this assay, from the lowest: compounds 2 and 1 (each within the scatter of the next); then compound 4. At a limit, above all of these: compound 3.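

Exchanging the group on the double-bonded nitrogen does register in this assay: with the rest of the structure unchanged, 2,5-difluorophenyl in place of 3-(trifluoromethyl)phenyl brings a 2.7-fold higher number from compound 1 to compound 4 (0.43 log units; beyond the scatter) and so moves the result modestly towards lower toxicity in this test. The earlier compounds shown here could not show this, since no two of them differed in one place, whereas this pair shows that the group at this position alone can shift the number beyond the scatter. Nothing among the data shown bears on why the step has this size.

From the compounds shown here alone, it remains open whether a phenyl ring carrying a nitrile or a carboxylic acid at this position would shift the number further, or in the opposite direction. A single step also cannot show whether the same exchange would have a similar effect on a different core.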